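Amide nitrogen methylation across a bromomethyl and aminomethyl pair

The compounds below may be only part of what the source reports. "The series", "measured", "known", "first", "only" and "open" are said of these compounds alone.

Of the compounds shown here, three of one series have been measured in an in vitro assay on UC11MG cells for binding affinity to Substance-P receptor (Homo sapiens), read by radioligand binding; a lower number here means a stronger inhibitor, a higher number a weaker inhibitor. Compound 1 `O=C(NCc1cc(C(F)(F)F)cc(C(F)(F)F)c1)c1c(CBr)nc2ccccc2c1-c1ccccc1` gives 0.01 nM. Compound 2 `CN(Cc1cc(C(F)(F)F)cc(C(F)(F)F)c1)C(=O)c1c(CBr)nc2ccccc2c1-c1ccccc1` gives 52 nM. Compound 3 `NCc1nc2ccccc2c(-c2ccccc2)c1C(=O)NCc1cc(C(F)(F)F)cc(C(F)(F)F)c1` gives 0.0017 nM, the lowest of the three numbers.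

Compound 2 differs from compound 1 by methyl in place of hydrogen on an amide-type nitrogen. This change produced a 5200-fold higher number from compound 1 to compound 2 (3.72 log units; beyond the scatter), the largest step in the set. Compound 3 differs from compound 1 by amino in place of bromo on a saturated chain carbon bound to an aromatic carbon; that change produced a 5.9-fold lower number from compound 1 to compound 3 (0.77 log units; beyond the scatter).

Compound 4 `CN(Cc1cc(C(F)(F)F)cc(C(F)(F)F)c1)C(=O)c1c(CN)nc2ccccc2c1-c1ccccc1` has not yet been measured in this assay. It differs from compound 3 by methyl in place of hydrogen on an amide-type nitrogen. The same change has already been made once, from compound 1 to compound 2, and the surroundings of the place are described in the same words in both cases, so it is taken to be the same change set on the core of compound 3 rather than the core of compound 1; how the two cores differ is given by amino in place of bromo on a saturated chain carbon bound to an aromatic carbon.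

Compound 4 is expected to show a step of about a 5300-fold higher number from compound 3 to compound 4 (3.72 log units; beyond the scatter) from compound 3 in this assay, because the same change once gave a 5200-fold higher number from compound 1 to compound 2 (3.72 log units; beyond the scatter). That expectation rests on a single prior example, so the range is set wide. Compound 4 is estimated at 9 nM in this assay, expected to fall between 1 nM and 80 nM.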

Compound 4, half-maximal inhibitory concentration: 9 nM
Estimate against measurement, compound 4: no gap at the digits printed, within the range that was stated.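

In this assay, methyl in place of hydrogen on the amide-type nitrogen gives a 5300-fold higher number from compound 3 to compound 4 (3.72 log units; beyond the scatter), and this step on the core of compound 3 matches the earlier step on the core of compound 1: the same change on two cores in this assay, a 5200-fold higher number (3.72 log units; beyond the scatter) from compound 1 to compound 2 and a 5300-fold higher number (3.72 log units; beyond the scatter) from compound 3 to compound 4, 1.0-fold (0.01 log units) apart, within the scatter of two such steps. Read the other way around the same set of compounds, amino in place of bromo gives a 5.8-fold lower number from compound 2 to compound 4 (0.76 log units; beyond the scatter) with the methyl present, matching the step seen with the amide hydrogen in place: the same change on two cores in this assay, a 5.9-fold lower number (0.77 log units; beyond the scatter) from compound 1 to compound 3 and a 5.8-fold lower number (0.76 log units; beyond the scatter) from compound 2 to compound 4, 1.0-fold (0.01 log units) apart, within the scatter of two such steps. Within compounds 1 to 4, each change therefore has the same size whichever form the other place takes, and no compound goes against this, but that is shown for one pair of cores in one assay only and gives neither a general rule for the series nor a cause for the large loss on methylation.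

The compounds shown leave open whether an ethyl group or a longer chain on the amide-type nitrogen gives a step of similar size to that of methyl. They also leave open whether the match between steps holds when a hydroxyl or a dimethylamino group stands in place of the amino or bromo group.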